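The source may hold more compounds than are shown below. What is called first, only, known or untested is meant among the compounds shown, and "the series" means these compounds.

Measured compounds:
- compound 1 `CCCN(C)C(=O)c1ccc(-c2cc(-c3cc(OC)ccc3OC)no2)s1`: > 30000 nM
- compound 2 `COc1ccc(OC)c(-c2cc(-c3ccc(C(=O)NCC4CC4)s3)on2)c1`: > 30000 nM

In a functional assay on A549 cells (Homo sapiens) for cytotoxicity, read by XTT assay, with a stated time of 72 h (a higher number here means a weaker inhibitor, a lower number a stronger inhibitor), compound 1 gives only a limit, > 30000 nM. In this assay compound 2 likewise gives only a limit, > 30000 nM. The step that the two limits leave unreadable from compound 1 to compound 2 is therefore not readable in size, since both of its ends are limits, and both values sit at the same limit (the limit of > 30000 nM in this assay, at which 2 of the 2 values shown sit). Within the data shown here, compound 2 thus stands at that limit, with no number of its own in this assay, and nothing measured so far places it either side of compound 1.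

Compound 3 `COc1ccc(OC)c(-c2cc(-c3ccc(C(=O)N(C)Cc4ccccc4)s3)on2)c1` differs from compound 2 in benzyl(methyl)amino in place of (cyclopropylmethyl)amino on a carbonyl carbon. Among the measured compounds shown here, the only measured step that bears on this position is a step that the two limits leave unreadable from compound 1 to compound 2, which gives no size. For the measured compounds named here, no measured compound carries a number in this assay, so there is no direction to read from the data. The expected step of a number no higher from compound 2 to compound 3 (the limit leaves the size open) is therefore none beyond the scatter. Compound 3 is estimated in this assay at 30000 nM, with a range from 8000 nM to 100000 nM, most likely again reported only as a limit.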

Compound 3, half-maximal inhibitory concentration: > 30000 nM
Compound 3 was reported as a limit; the forecaster's own chance of this, stated with the estimate: 75%; the middle value sits exactly at the limit.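

In this assay compound 3 gives > 30000 nM, which is a limit and not a number. Among these compounds, no step among compound 1, compound 2 and compound 3 can be read, since every value is a limit: the limit of > 30000 nM in this assay, at which 3 of the 3 values shown sit. The compounds shown leave open which group on the carbonyl carbon, if any, would give a readable number in this assay.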